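Thiophen-2-yl to Pyridin-3-yl: Expecting Compound 4

The source may report more compounds than this note shows. Statements on the series, on what has been measured and on what is new or still open speak of the compounds shown alone.

Compound 1, `Oc1ccc(-c2cc(-c3cccnc3)nc(-c3ccccc3Cl)c2)cc1`: in a functional assay on T47D cells (Homo sapiens) for cytotoxicity, read by CCK-8 assay and cell counting, with a stated time of 2 days (a lower number here means a stronger inhibitor, a higher number a weaker inhibitor), compound 1 gives "not determined" (no result reported).
Compound 2, `Oc1ccc(-c2cc(-c3ccncc3)nc(-c3ccc(Cl)cc3)c2)cc1`: in this assay compound 2 gives "not determined" (no result reported).
Compound 3, `Oc1ccc(-c2cc(-c3ccc(Cl)cc3)nc(-c3cccs3)c2)cc1`: in this assay compound 3 gives 6450 nM.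

Among these three compounds, compound 3 is the only one with a number; the other two carry no result at all. Compound 4, `Oc1ccc(-c2cc(-c3ccc(Cl)cc3)nc(-c3cccnc3)c2)cc1`, differs from compound 3 in one place: pyridin-3-yl in place of thiophen-2-yl on an aromatic carbon. The thiophen-2-yl group leaves and a pyridin-3-yl group enters, on an aromatic carbon next to the ring nitrogen of the shared core. For the measured compounds named here, no pair of measured compounds shows how such a swap shifts this assay, so the step of a 1.1-fold lower number from compound 3 to compound 4 (0.03 log units; within the scatter) is expected to stay within the usual scatter, in no particular direction. Compound 4 is therefore estimated at 6000 nM, with a range from 2000 nM to 20000 nM.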

Compound 4, half-maximal inhibitory concentration: 29300 nM
The estimate for compound 4 lay 4.9-fold (0.69 log units) below the measured number, outside the stated range (above it).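

In this assay, for the compounds shown here, putting pyridin-3-yl in place of thiophen-2-yl next to the ring nitrogen gives a 4.5-fold higher number from compound 3 to compound 4 (0.66 log units; beyond the scatter), the first readable step. It shows that this position is sensitive to which aromatic ring it carries, with thiophen-2-yl giving the lower number of the two. No measurement at hand explains the shift.

This is a single pair, so it cannot show a trend across ring types. Going by these compounds, whether a plain phenyl ring, an amine or a carboxylic acid at this position would lower or raise the number remains open.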